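Chalcone amide series: swapping chlorophenyl for methoxyphenyl

This account rests on a few compounds, and the source may have more. Where it says the series, first, only, none or still open, it means among the compounds named here.

Measured compounds:
- compound 1, `O=C(CN1CCN(c2cc3c(cc2F)c(=O)c(C(=O)O)cn3C2CC2)CC1)Nc1ccc(C(=O)/C=C/c2ccccc2)cc1`: 6.4%
- compound 2, `O=C(CN1CCN(c2cc3c(cc2F)c(=O)c(C(=O)O)cn3C2CC2)CC1)Nc1ccc(C(=O)/C=C/c2cccc(Cl)c2)cc1`: 3.1%
- compound 3, `O=C(CN1CCN(c2cc3c(cc2F)c(=O)c(C(=O)O)cn3C2CC2)CC1)Nc1ccc(C(=O)/C=C/c2ccc(Cl)cc2)cc1`: 0.4%

All three share one core and differ only in the aromatic ring at the end of the double-bonded chain. In an assay on isolated protein for inhibition of DNA topoisomerase 1 (Homo sapiens), with a stated time of 30 min, tested at 20 uM (on this read-out lower numbers stand for a weaker effect and higher numbers for a stronger effect at the one concentration tested), compound 1 gives 6.4%, and the two chlorinated relatives sit close by. Compound 2 stands among the three with its neighbours on either side no further than the usual scatter: a number 3.3 percentage points lower from compound 1 to compound 2 (within the scatter) and a number 2.7 percentage points lower from compound 2 to compound 3 (within the scatter). The widest gap, a number 6 percentage points lower from compound 1 to compound 3 (within the scatter), is also within the scatter. So far, then, nothing in this group has moved the read-out in a way that can be told apart from noise.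

Compound 4, `COc1ccc(/C=C/C(=O)c2ccc(NC(=O)CN3CCN(c4cc5c(cc4F)c(=O)c(C(=O)O)cn5C4CC4)CC3)cc2)cc1`, is not yet measured. Compared with compound 2 it carries 4-methoxyphenyl in place of 3-chlorophenyl on a double-bonded chain carbon bound to a double-bonded chain carbon. Among the compounds with values here, the steps that bear on this are those touching the same ring, a number 2.7 percentage points lower from compound 2 to compound 3 (within the scatter) and a number 3.3 percentage points lower from compound 1 to compound 2 (within the scatter), both small. Within the data shown here, no step in this group exceeds the scatter, so no step beyond it is expected in this assay here either; the expected change from compound 2 is a number 0.9 percentage points higher from compound 2 to compound 4 (within the scatter). Compound 4 is therefore estimated at 4%, within a range of 0% to 12%.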

Compound 4, a percentage reported as inhibition, at one concentration (the size of the read-out at that concentration, not a potency): 25.3%
For compound 4 the middle estimate is 21.3 percentage points below the measured one; the measured number lies above the stated range.
By their numbers in this assay, from the lowest: compounds 3, 2 and 1 (each within the scatter of the next); then compound 4.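

In this assay the aromatic ring on the double-bonded chain carbon turns out to be able to shift the read-out, with a number 18.9 percentage points higher from compound 1 to compound 4 (beyond the scatter) once methoxy replaces hydrogen on an aromatic carbon. The comparison with the chlorinated relatives points the same way, with a number 22.2 percentage points higher from compound 2 to compound 4 (beyond the scatter) for 4-methoxyphenyl in place of 3-chlorophenyl and a number 24.9 percentage points higher from compound 3 to compound 4 (beyond the scatter) for methoxy in place of chloro on an aromatic carbon. So this ring is not indifferent to what it carries: chloro in place of hydrogen stayed within the scatter and methoxy did not, although the steps remain modest and come from a single tested concentration, which gives the size of an effect and not a potency.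

From the compounds shown here alone, it remains open whether the methoxy group must sit where it does in 4-methoxyphenyl, and whether a hydroxy group, an amine or a longer ethoxy chain on the same ring would give a similar read-out. No measurement available here explains why methoxy stands apart from chloro and hydrogen.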